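The compounds below may be only part of what the source reports. "The series", "measured", "known", "first", "only" and "open" are said of these compounds alone.

Working notes on the series. Compound 1 `Cc1nnc(SCC(=O)c2ccc(Cl)cc2)n1N1C(=O)c2ccccc2C1=O` sits at the assay limit in a functional assay on MKN-45 cells (Homo sapiens) for cytotoxicity, read by MTT assay, with a stated time of 48 h (a lower number here means a stronger inhibitor, a higher number a weaker inhibitor), giving > 200000 nM. Compound 2 `Cc1nnc(SCC(=O)c2ccccc2)n1N1C(=O)c2ccccc2C1=O` likewise sits at the assay limit in this assay, giving > 200000 nM. The step from one to the other, a step that the two limits leave unreadable from compound 1 to compound 2, is hidden by the two limits. Where compound 2 stands is therefore known only as a limit; no numbered value exists in the set, since both values shown sit at the limit of > 200000 nM in this assay, at which 2 of the 2 values shown sit.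

Compound 3 `C#CCSc1nnc(C)n1N1C(=O)c2ccccc2C1=O` differs from compound 2 by ethynyl in place of benzoyl on a saturated chain carbon bound to a sulfur. Among the measured compounds shown here, no measured step bears on this change: the one step in hand touches a chloro on the aromatic ring of the benzoyl arm, and the arm itself is now removed. Nothing in the two values argues for a departure from the limit. Compound 3 is expected to give about 200000 nM in this assay, within 60000 nM to 600000 nM, most likely again reported as a limit. The expected step of a number no higher from compound 2 to compound 3 (the limit leaves the size open) is accordingly none beyond the scatter.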

Compound 3, half-maximal inhibitory concentration: > 200000 nM
Compound 3: no number, only a limit; the forecaster's own chance of this, stated with the estimate: 85%; the middle value lies on the limit itself.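

Compound 3 also gives only a limit, > 200000 nM in this assay. No step among compound 1, compound 2 and compound 3 can be read: the limit of > 200000 nM in this assay, at which 3 of the 3 values shown sit.

The compounds shown leave open whether any group on the saturated chain carbon bound to a sulfur gives a numbered value in this assay.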